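Quinoline Amides: From a Methylphenyl to a Fluorophenyl

This account rests on a few compounds, and the source may have more. Where it says the series, first, only, none or still open, it means among the compounds named here.

Measured compounds:
compound 1 `COc1ccc2nc(C)cc(NCC(=O)Nc3cc(C)cc(C)c3)c2c1`, 3.59
compound 2 `COc1ccc2nc(C)cc(OCC(=O)Nc3cccc(C)c3)c2c1`, 4.83
compound 3 `COc1ccc2nc(C)cc(OCC(=O)Nc3cc(OC)c(OC)c(OC)c3)c2c1`, 3.95

In a physicochemical assay for lipophilicity, read by HPLC, in phosphate buffer, measured as chromatographic lipophilicity, at pH 7.4 (on this read-out higher numbers stand for higher lipophilicity and lower numbers for lower lipophilicity), compound 2 stands highest of the three numbers; compound 3 lies nearer to it and compound 1 furthest, both gaps beyond the scatter. The step taken here leads from compound 2 to compound 4 `COc1ccc2nc(C)cc(OCC(=O)Nc3ccc(F)cc3)c2c1`, which has not been measured in this assay. The change is 4-fluorophenyl in place of 3-methylphenyl on an amide-type nitrogen.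

Going by the values given here, no measured pair differing in one place is available, so the size of this step is uncertain. Compound 4 is expected to fall somewhat lower than compound 2, by a step of a number 0.38 log units lower from compound 2 to compound 4 (beyond the scatter) in this assay, beyond the scatter but modest. Compound 4 is therefore estimated at 4.45, within a range of 4.1 to 4.8.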

Compound 4, distribution coefficient: 4.49
Compound 4: middle estimate off by 0.04 log units, on the low side; low and high end bracket the measured number.
By their numbers in this assay, from the lowest: compound 1; then compound 3; then compound 4; then compound 2.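

Going by these compounds alone, measured in this assay the change of 3-methylphenyl to 4-fluorophenyl on an amide-type nitrogen reads as a number 0.34 log units lower from compound 2 to compound 4 (beyond the scatter) and gives the first pair here that differs in one place. This position therefore responds to the swap, with a modest step. Nothing shown here gives a reason for that step.

The compounds leave open how an unsubstituted phenyl or a 4-methylphenyl would read on that nitrogen, so the step cannot yet be divided between the two groups. They also leave open whether the same swap gives a similar step on the core of compound 1.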